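Propyl to 3-nitrophenyl on the shared core

The source may report more compounds than this note shows. Statements on the series, on what has been measured and on what is new or still open speak of the compounds shown alone.

For the measured compounds named here, compound 1 `CCCC1C(C(=O)OCc2ccccn2)=C(C)NC2=C1C(=O)CCC2` is the more lipophilic of the two measured members: in a physicochemical assay for lipophilicity, measured as octanol-water partition (on this read-out lower numbers stand for lower lipophilicity and higher numbers for higher lipophilicity), compound 1 gives 2.6, while compound 2 `CC1=C(C(=O)OCc2cccnc2)C(c2ccc(Cl)cc2)C2=C(CCCC2=O)N1` gives 1.87, a gap beyond the scatter. Compound 3 `CC1=C(C(=O)OCc2ccccn2)C(c2cccc([N+](=O)[O-])c2)C2=C(CCCC2=O)N1` is not yet measured; it differs from compound 1 by 3-nitrophenyl in place of propyl on a saturated ring carbon. Going by the values given here, no measured pair isolates this change. A modest downward step from compound 1 to compound 3 is expected, a number 0.50 log units lower from compound 1 to compound 3 (beyond the scatter), near the edge of the scatter. Compound 3 is therefore estimated at 2.1, within 1.4 to 2.8.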

Compound 3, partition coefficient: 1.88
Estimate against measurement, compound 3: 0.22 log units above; low and high end bracket the measured number.
By their numbers in this assay, from the lowest: compounds 2 and 3 (each within the scatter of the next); then compound 1.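

For the compounds shown here, on the saturated ring carbon of the shared core, 3-nitrophenyl in place of propyl gives the first step in this assay that isolates a single change: a number 0.72 log units lower from compound 1 to compound 3 (beyond the scatter). Going by these compounds alone, the position therefore responds to this change by more than the scatter, which the earlier compounds, differing in more than one place, could not show. Nothing available gives a reason for the step.

As far as these compounds go, whether the step follows the aromatic ring or the nitro group stays open. Plain phenyl or a longer chain such as hexyl at this carbon would be the informative comparisons.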